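The source may report more compounds than this note shows. Statements on the series, on what has been measured and on what is new or still open speak of the compounds shown alone.

Series notes, step from compound 3 to compound 4.

Compound 3 `CCOc1ccc(NC2=C(C(=O)c3ccccc3)C(c3ccc(Br)cc3)N(CCCn3ccnc3)C2=O)cc1` gives 20200 nM in a functional assay on A549 cells (Homo sapiens) for antiproliferative activity, read by MTT assay, with a stated time of 72 h (a lower number here means a stronger inhibitor, a higher number a weaker inhibitor), and has the lowest of the two numbers in hand. Its nearest neighbour is compound 2 `Cc1ccc(NC2=C(C(=O)c3ccccc3)C(c3ccc(Br)cc3)N(CCCn3ccnc3)C2=O)cc1`, which gives 29400 nM; the two lie within the scatter of each other, so no order between them is claimed. Compound 1 `NC1=C(C(=O)c2ccccc2)C(c2ccc(Br)cc2)N(CCCn2ccnc2)C1=O`, carrying the unsubstituted amine, is reported as "not active" (no number reported) in this assay, with no number given.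

Within the data shown here, only one step between measured compounds exists, a 1.5-fold lower number from compound 2 to compound 3 (0.16 log units; within the scatter), and it concerns a substituent on the aromatic ring, not the point changed here.

Compound 4 `O=C(C1=C(NCc2ccccc2)C(=O)N(CCCn2ccnc2)C1c1ccc(Br)cc1)c1ccccc1` differs from compound 3 as benzyl in place of 4-ethoxyphenyl on an amine nitrogen. Among the measured compounds shown here, no measured step bears on exchanging the aryl group on the amine nitrogen for benzyl; the single measured step was flat. For compound 4 the expectation is therefore a step of a 1.2-fold higher number from compound 3 to compound 4 (0.09 log units; within the scatter), that is, no change beyond the scatter, with wide uncertainty, and a value estimated at 25000 nM, within a range from 8000 nM to 80000 nM.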

Compound 4, half-maximal inhibitory concentration: 52800 nM
The estimate for compound 4 lay 2.1-fold (0.32 log units) below the measured number, and the stated range covers the measured number.
By their numbers in this assay, from the lowest: compounds 3, 2 and 4 (each within the scatter of the next, the first and the last beyond it).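

Among these compounds, exchanging the aromatic group on the amine nitrogen for benzyl gives the first step beyond the scatter in this assay: a 2.6-fold higher number from compound 3 to compound 4 (0.42 log units; beyond the scatter). With 4-methylphenyl as the group leaving, the step reads a 1.8-fold higher number from compound 2 to compound 4 (0.25 log units; within the scatter), so the change separates benzyl from 4-ethoxyphenyl but not from 4-methylphenyl, and no general penalty for benzyl at this position can be claimed. Nothing measured here accounts for either step.

Still open, on these data alone, is how a longer chain between the phenyl ring and the amine nitrogen, such as 2-phenylethyl, or a saturated ring such as cyclohexyl, would read in this assay. Also open, as far as these compounds go, is whether a substituent on the benzyl ring, such as methoxy or chlorine, would shift the number of compound 4.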